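A chain amide replaces isopropyl: what compound 4 might give

A few compounds are considered here, and "the series" means these few. Any claim that something is new, unique, unknown or untested is made for them only; others in the source may bear on it.

Compound 1, `O=C(CN(c1nc(Cl)nc2[nH]cnc12)C1CC1)NCC(=O)OCc1ccccc1`, gives 21.7% in a functional assay on the whole organism (Tail, strain ICR) with Mus musculus as the target, in the tail flick test, with a stated time of 120 min, at a dose of 25 umol/kg by the oral route; a lower number here means a weaker effect, a higher number a stronger effect of the compound at the dose given.
Compound 2, `O=C(CN(c1nc(Cl)nc2[nH]cnc12)C1CC1)N[C@@H](CCC(=O)OCc1ccccc1)C(=O)OCc1ccccc1`, gives 45.9%.
Compound 3, `CC(C)[C@H](NC(=O)CN(c1nc(Cl)nc2[nH]cnc12)C1CC1)C(=O)OCc1ccccc1`, gives 27.3%.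

Compound 3 stands second highest of the three: its number lies within the scatter of compound 1 and beyond the scatter below compound 2. Compound 4, `NC(=O)CC[C@H](NC(=O)CN(c1nc(Cl)nc2[nH]cnc12)C1CC1)C(=O)OCc1ccccc1`, differs from compound 3 by 2-carbamoylethyl in place of isopropyl on a saturated chain carbon bound to an amide-type nitrogen and a carbonyl carbon. The step that bears on this is a number 18.6 percentage points lower from compound 2 to compound 3 (beyond the scatter), which shows that a longer chain bearing a carbonyl on this carbon gave a higher number than isopropyl, while a number 5.6 percentage points higher from compound 1 to compound 3 (within the scatter) shows isopropyl itself hardly differs from hydrogen. The entering group carries an amide rather than the benzyl ester of compound 2, and a smaller step than that one is expected. Compound 4 is expected to show a number 7.7 percentage points higher from compound 3 to compound 4 (within the scatter). Compound 4 is estimated at 35%, within 18% to 55%.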

Compound 4, a percentage reported as activity, at one dose (the size of the read-out at that dose, not a potency): 36%
Estimate against measurement, compound 4: 1 percentage points below; measured number inside the range.
By their numbers in this assay, from the lowest: compounds 1, 3, 4 and 2 (each within the scatter of the next, the first and the last beyond it).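

In this assay 2-carbamoylethyl on this saturated chain carbon gives a number 14.3 percentage points higher from compound 1 to compound 4 (beyond the scatter) and so separates from hydrogen without a benzyl ester on the side chain, though a number 8.7 percentage points higher from compound 3 to compound 4 (within the scatter) does not separate it from isopropyl. Amino in place of benzyloxy on a carbonyl carbon gives a number 9.9 percentage points lower from compound 2 to compound 4 (within the scatter) so that change is not separated from the ester of compound 2 either. No measurement shown accounts for these steps.

As far as these compounds go, whether a carboxylic acid or a longer chain in place of 2-carbamoylethyl would stand beyond the scatter of compound 2 remains open.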